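The source may report more compounds than this note shows. Statements on the series, on what has been measured and on what is new or still open speak of the compounds shown alone.

Measured compounds:
compound 1 `NC(=O)c1c(NC(=O)c2ccccc2Cl)sc2c1CCN(Cc1ccc(Cl)cc1Cl)C2`: 16300 nM
compound 2 `Cc1ccc(C(=O)Nc2sc3c(c2C(N)=O)CCN(Cc2ccc(Cl)cc2Cl)C3)cc1`: 25500 nM
compound 3 `NC(=O)c1c(NC(=O)c2cccc([N+](=O)[O-])c2)sc2c1CCN(Cc1c(Cl)cccc1Cl)C2`: 13500 nM

All three numbers come from a functional assay on MKN-74 cells (Homo sapiens) for antiproliferative activity, with a stated time of 24 h; a lower number here means a stronger inhibitor, a higher number a weaker inhibitor. Compound 3 carries the lowest number of the three, yet its gaps to compound 1 and to compound 2 both lie within the scatter, so no ordering is drawn. Compound 4 `NC(=O)c1c(NC(=O)c2cccc([N+](=O)[O-])c2)sc2c1CCN(Cc1ccc(Cl)cc1Cl)C2` differs from compound 3 only in 2,4-dichlorophenyl in place of 2,6-dichlorophenyl on a saturated chain carbon bound to an amine nitrogen in a ring. Among the compounds with values here, the single measured step, a 1.6-fold higher number from compound 1 to compound 2 (0.19 log units; within the scatter), alters the group on the carbonyl carbon, not the group on the saturated chain carbon, so it touches the present change only indirectly: it shows the series moving little so far. Compound 1 and compound 2 carry the 2,4-dichlorobenzyl group of compound 4 and sit close to compound 3, which also points to little movement. The step of a 1.1-fold higher number from compound 3 to compound 4 (0.05 log units; within the scatter) is therefore expected to remain within the scatter. Compound 4 is estimated at 15000 nM, range 6000 nM to 40000 nM.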

Compound 4, half-maximal inhibitory concentration: 16500 nM
Compound 4: middle estimate off by 1.1-fold (0.04 log units), on the low side; the range from low to high includes it.
By their numbers in this assay, from the lowest: compounds 3, 1, 4 and 2 (each within the scatter of the next).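

In this assay, within the data shown here, the first reading at the saturated chain carbon bound to the ring amine nitrogen, 2,4-dichlorobenzyl in place of 2,6-dichlorobenzyl gives a 1.2-fold higher number from compound 3 to compound 4 (0.09 log units; within the scatter), so these two chlorine patterns do not separate. With 2,4-dichlorobenzyl held, 3-nitrophenyl on the carbonyl carbon does not separate from the other two aryl groups either, giving a 1.5-fold lower number from compound 2 to compound 4 (0.19 log units; within the scatter) and a 1.0-fold higher number from compound 1 to compound 4 (0.01 log units; within the scatter). No available evidence bears on this result.

As far as these compounds go, whether an unsubstituted benzyl group, or a benzyl group carrying an amine or a carboxylic acid, would depart from these values remains open.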